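The source may report more compounds than this note shows. Statements on the series, on what has been measured and on what is new or still open speak of the compounds shown alone.

compound 1 `Fc1cccc(-c2nc(Nc3ccc(Cl)cc3)c3cc(F)ccc3n2)c1`: 40300 nM
compound 2 `Fc1cccc(-c2nc(Nc3ccccc3Cl)c3cc(F)ccc3n2)c1`: > 50000 nM (a limit)
compound 3 `Fc1cccc(-c2nc(Nc3cccc(Br)c3)c3cc(F)ccc3n2)c1`: > 50000 nM (a limit)

In a functional assay on HT29-AK cells (Homo sapiens) for cytotoxicity, read by MTT assay, with a stated time of 48 h (on this read-out higher numbers stand for weaker inhibition and lower numbers for stronger inhibition), compound 3 gives > 50000 nM, which is a limit and not a number. The series is largely defined by the limit of > 50000 nM in this assay, at which 2 of the 3 values shown sit.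

In compound 4 `Oc1ccc(Nc2nc(-c3cccc(F)c3)nc3ccc(F)cc23)cc1`, 4-hydroxyphenyl stands in place of 3-bromophenyl on a nitrogen on an aromatic ring (4-hydroxyphenyl in place of 3-bromophenyl on a nitrogen on an aromatic ring).

The measured steps at this place are an at least 1.2-fold higher number from compound 1 to compound 2 (0.09 log units; that floor lies within the scatter) and an at least 1.2-fold higher number from compound 1 to compound 3 (0.09 log units; that floor lies within the scatter), and the third is a step that the two limits leave unreadable from compound 2 to compound 3. Going by the values given here, the only actual number belongs to compound 1, with 4-chlorophenyl, at 40300 nM. A small move towards a lower number is therefore expected, an at least 1.4-fold lower number from compound 3 to compound 4 (0.15 log units; that floor lies within the scatter). For compound 4 the estimated value is 35000 nM, with an expected range of 12000 nM to 60000 nM.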

Compound 4, half-maximal inhibitory concentration: > 50000 nM
Compound 4 gave a limit, no number; the forecaster's own chance of this, stated with the estimate: 50%; middle value at least 1.4-fold (0.15 log units) from the limit.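

In this assay, hydroxy in place of chloro on an aromatic carbon gives an at least 1.2-fold higher number from compound 1 to compound 4 (0.09 log units; that floor lies within the scatter), so this change shows no readable gain. At this place, a 4-hydroxyphenyl group with a hydrogen-bond donor and acceptor leaves the result at the assay limit, as 2-chlorophenyl and 3-bromophenyl did. The steps to compound 4 from compound 2 and from compound 3 cannot be read, and the series now rests largely on one limit: the limit of > 50000 nM in this assay, at which 3 of the 4 values shown sit.

As far as these compounds go, whether an amine or a carboxylic acid on this ring would give a number under that limit stays open. From the compounds shown here alone, how far compound 4 truly lies from compound 1 also stays open.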